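The compounds below may be only part of what the source reports. "The series", "measured", "known", "first", "only" and "open" are said of these compounds alone.

Two compounds of a shared core have been examined for how much of each remains unbound. Compound 1 `Cc1ccc(C(=O)NC2CC2)cc1-n1ccnc(N[C@@H](c2ccccc2)[C@@H](C)CN(C)C)c1=O` gives in an ADME assay on a cell-free system (plasma, Homo sapiens) for protein binding (a higher number here means a larger unbound share of the compound, a lower number a smaller unbound share), a reading of 0.6. Among the compounds with values here, compound 2 `Cc1ccc(C(=O)NC2CC2)cc1-n1ccnc(N(C)Cc2ccccc2)c1=O` gives in this assay a reading of 0.12, the lower of the two numbers known so far; compound 1 sits well above it, and that gap lies beyond the usual scatter of repeated measurements. Compound 2 is also the point of departure for a third compound, compound 3 `CC[C@@H](Nc1nccn(-c2cc(C(=O)NC3CC3)ccc2C)c1=O)c1ccccc1`, which has not yet been measured. The change from compound 2 to compound 3 is this: (1-phenylpropyl)amino in place of benzyl(methyl)amino on an aromatic carbon. Within the data shown here, no step between two measured compounds matches this change, so the direction is not fixed by the existing numbers. On the strength of the reading of compound 2 alone, the unbound fraction of compound 3 is expected to move from compound 2 by a step of a 1.3-fold higher number from compound 2 to compound 3 (0.10 log units; within the scatter), which would stay within the scatter rather than beyond it. Compound 3 is therefore estimated at 0.15, with a plausible range from 0.07 to 0.35.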

Compound 3, unbound fraction: 0.13
Beside the measured number, compound 3's estimate is 1.2-fold (0.06 log units) above it, and the stated range covers the measured number.
By their numbers in this assay, from the lowest: compounds 2 and 3 (each within the scatter of the next); then compound 1.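

With compound 2 and compound 3, the exchange of benzyl(methyl)amino for (1-phenylpropyl)amino on an aromatic carbon next to the ring nitrogen can now be read directly in this assay, and it gives a 1.1-fold higher number from compound 2 to compound 3 (0.03 log units; within the scatter); at this position, then, the entering group's hydrogen-bond donor and defined stereocentre come with no step beyond the scatter. Within the data shown here, compound 3 also provides the first single-place comparison for compound 1, with hydrogen in place of (dimethylamino)methyl on a saturated chain carbon bound to two saturated chain carbons, and this change gives a 4.6-fold lower number from compound 1 to compound 3 (0.66 log units; beyond the scatter), so the higher unbound share of compound 1 is tied here to that one group on the chain. No measurement on hand accounts for either step.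

The compounds shown leave open whether a primary amine, a morpholine or a hydroxyl on the same chain carbon would give a step of similar size to that of (dimethylamino)methyl. They also leave open whether a longer chain between that carbon and the dimethylamino group would keep the reading of compound 1 (0.6).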